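Benzyl for phenyl on the amide nitrogen of compound 1

The source may hold more compounds than are shown below. What is called first, only, known or untested is meant among the compounds shown, and "the series" means these compounds.

Measured so far in an ADME assay on SW480 cells (Homo sapiens) for cytotoxicity, read by MTT assay, with a stated time of 72 h; a higher number here means a weaker inhibitor, a lower number a stronger inhibitor:
compound 1, `O=C(Nc1ccccc1)c1cccc(/C=C2\CC(=O)N(c3ccccc3)C2=O)c1` — compound 1 gives > 100000 nM, which is a limit of the assay.
compound 2, `CCc1cccc(NC(=O)c2cccc(/C=C3\CC(=O)N(c4ccc(C)cc4)C3=O)c2)c1` — compound 2 gives 65300 nM.
compound 3, `CCCCNC(=O)c1cccc(/C=C2\CC(=O)N(Cc3ccccc3)C2=O)c1` — compound 3 gives > 100000 nM, also a limit.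

Compound 1 stands at the limit of > 100000 nM in this assay, at which 2 of the 3 values shown sit; it is a limit, not a number, so its place relative to compound 2 cannot be set. Compound 4, `O=C(NCc1ccccc1)c1cccc(/C=C2\CC(=O)N(c3ccccc3)C2=O)c1`, differs from compound 1 by benzyl in place of phenyl on an amide-type nitrogen. For the measured compounds named here, no step between measured compounds is available to show what this change does in this assay. The expected step of a number no higher from compound 1 to compound 4 (the limit leaves the size open) is none beyond the scatter. Compound 4 is expected at 100000 nM, within 40000 nM to 250000 nM. A limit rather than a number is the likelier report for compound 4.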

Compound 4, half-maximal inhibitory concentration: > 100000 nM
Compound 4 was reported as a limit; the forecaster's own chance of this, stated with the estimate: 70%; the middle value sits exactly at the limit.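

Compound 1 and compound 4 are both reported as limits in this assay, so no step between them can be read: the limit of > 100000 nM in this assay, at which 3 of the 4 values shown sit.

As far as these compounds go, whether benzyl in place of phenyl on an amide-type nitrogen changes the half-maximal inhibitory concentration at all remains open.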